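Chloro removal and cell tolerance across two cores

The source may hold more compounds than are shown below. What is called first, only, known or untested is meant among the compounds shown, and "the series" means these compounds.

Measured in an ADME assay on BHK-21 cells (Mesocricetus auratus) for cytotoxicity, with a stated time of 3 days; a lower number here means that less compound is tolerated, a higher number that more compound is tolerated:
compound 1 `O=C(CCSc1nnc(-c2ccncc2)s1)Nc1c(Cl)cccc1Cl`: 10300 nM
compound 2 `O=C(CCSc1nnc(-c2ccncc2)s1)Nc1ccccc1Cl`: > 50000 nM, a limit of this assay
compound 3 `CC(CSc1nnc(-c2ccncc2)s1)C(=O)NCc1ccc(Cl)cc1`: "not determined" (no result reported)

Compound 1 and compound 2 share one core; compound 3 and the unmeasured compound 4 `CC(CSc1nnc(-c2ccncc2)s1)C(=O)NCc1ccccc1` share another, and the difference between the two cores is not broken down here. The change hydrogen in place of chloro on an aromatic carbon gives an at least 4.8-fold higher number from compound 1 to compound 2 (0.68 log units; beyond the scatter), and the step reads as a lower bound because compound 2 sits at the limit of > 50000 nM in this assay, at which 1 of the 3 values shown sits. The change hydrogen in place of chloro on an aromatic carbon is the same kind of change, but the ring around it differs: in compound 1 the leaving chloro sits ortho to a large group and meta to a chloro group, whereas in compound 3 it sits para to a large group. For compound 4 a step of similar direction is expected, carried by compound 1 to compound 2 an at least 4.8-fold higher number from compound 1 to compound 2 (0.68 log units; beyond the scatter), though no measured value for compound 3 anchors it. Compound 4 is therefore expected to give about 40000 nM in this assay, estimated between 15000 nM and 80000 nM.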

Compound 4, half-maximal cytotoxic concentration: > 50000 nM
Compound 4 ended at the assay's limit; the forecaster's own chance of this, stated with the estimate: 50%; at least 1.2-fold (0.09 log units) between middle value and limit.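

Among the compounds shown here, compound 3 reads "not determined" (no result reported) in this assay, so no step to compound 4 can be read. Compound 4 gives > 50000 nM, which is a limit and not a number. Still open, on these data alone, is whether going from 4-chlorobenzyl to benzyl on this core shifts cell tolerance in the same direction as the chloro removal from compound 1 to compound 2.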